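The source may report more compounds than this note shows. Statements on the series, on what has been measured and on what is new or still open speak of the compounds shown alone.

Measured so far in a functional assay on CCRF-CEM cells (Homo sapiens) for cytotoxicity, in the presence of a further agent that is not named here; on this read-out higher numbers stand for weaker inhibition and lower numbers for stronger inhibition:
- compound 1 `Nc1nc(N)c(CCCN(Cc2ccc(NC(CCC(=O)O)C(=O)O)cc2)c2cc(F)c(F)cc2[N+](=O)[O-])c(O)n1`; compound 1 gives > 100000 nM, a limit of the assay.
- compound 2 `COC(=O)c1ccc(CN(CCCc2c(N)nc(N)nc2O)c2cc(F)ccc2[N+](=O)[O-])cc1`; compound 2 gives 30000 nM.
- compound 3 `Nc1nc(N)c(CCCN(Cc2ccc(NC(CCC(=O)O)C(=O)O)cc2)c2cc(F)c([N+](=O)[O-])cc2[N+](=O)[O-])c(O)n1`; compound 3 gives 43000 nM.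

Compound 3 holds the highest of the two numbers shown; compound 2 lies nearest, within the scatter, and the value of compound 1 is a limit of > 100000 nM in this assay, at which 1 of the 3 values shown sits, rather than a number.

Compound 4 `Nc1nc(N)c(CCCN(Cc2ccc(NC(CCC(=O)O)C(=O)O)cc2)c2cc(F)ccc2[N+](=O)[O-])c(O)n1` is not yet measured. It differs from compound 3 by hydrogen in place of nitro on an aromatic carbon.

Going by the values given here, one measured step bears on this change: the step of an at least 2.3-fold lower number from compound 1 to compound 3 (0.36 log units; beyond the scatter), where nitro in place of fluoro at the same position lowered the number. Compound 4 removes that nitro again, leaving hydrogen, so a movement back toward a higher number is expected, though compound 2, which carries the same fluoro and nitro pattern as compound 4 on that ring, gives a number close to compound 3. The step from compound 3 to compound 4 is therefore expected to be modest, a 1.4-fold higher number from compound 3 to compound 4 (0.14 log units; within the scatter), toward a higher number. Compound 4 is estimated at 60000 nM, within 20000 nM to 150000 nM.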

Compound 4, half-maximal inhibitory concentration: > 100000 nM
Compound 4 was reported as a limit; the forecaster's own chance of this, stated with the estimate: 25%; middle value at least 1.6-fold (0.22 log units) away from the limit.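

In this assay compound 4 gives a limit and not a number (> 100000 nM). With the (1,3-dicarboxypropyl)amino group held, nitro is the only one of the three groups shown on this aromatic carbon, ortho to a fluoro group, that gives a readable number: hydrogen in its place gives an at least 2.3-fold higher number from compound 3 to compound 4 (0.36 log units; beyond the scatter) and so mirrors the earlier step with fluoro (an at least 2.3-fold lower number from compound 1 to compound 3 (0.36 log units; beyond the scatter)). With hydrogen on this carbon, (1,3-dicarboxypropyl)amino in place of methoxycarbonyl gives an at least 3.3-fold higher number from compound 2 to compound 4 (0.52 log units; beyond the scatter), while the step between compound 1 and compound 4 cannot be read: the limit of > 100000 nM in this assay, at which 2 of the 4 values shown sit.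

Going by these compounds, how far compound 1 and compound 4 lie past that limit stays open. Also open, on these data alone, is whether an amine or a nitrile on this carbon would give a readable number, and whether a plain carboxylic acid in place of methoxycarbonyl would do so.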